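The compounds below may be only part of what the source reports. "The series", "measured", "known", "first", "only" and "open" are said of these compounds alone.

Four compounds built on one shared core are compared here, the last of them not yet tested. Compound 1 `COc1ccc(-c2cc3ccccc3c(-c3cccc(O)c3)n2)cc1` and compound 2 `COc1ccc(-c2cc3ccccc3c(-c3cccc(OC)c3)n2)cc1` differ in a single place, (methyl in place of hydrogen on an oxygen on an aromatic ring). Compound 3 `COc1ccc(-c2cc3cc(C)ccc3c(-c3cccc(O)c3)n2)cc1OC` carries a different core from compound 1, and that difference between the two cores is not broken down here. Compound 4 `COc1cccc(-c2nc(-c3ccc(OC)c(OC)c3)cc3cc(C)ccc23)c1` stands to compound 3 as compound 2 stands to compound 1: the change is methyl in place of hydrogen on an oxygen on an aromatic ring, hydroxy to methoxy, and it sits in the same surroundings in both pairs, so it is the same change made on a different core.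

In a functional assay on HCT-15 cells (Homo sapiens) for cytotoxicity, read by CCK-8 assay and cell counting, with a stated time of 72 h (a lower number here means a stronger inhibitor, a higher number a weaker inhibitor), compound 1 gives 1200 nM and compound 2 gives 1300 nM. Compound 3 gives 370 nM, the lowest number of the three, and its steps to compound 1 and to compound 2 both lie beyond the scatter. The change from hydroxy to methoxy has been measured once so far: a 1.1-fold higher number from compound 1 to compound 2 (0.03 log units; within the scatter), a step too small to count as a real change.

For compound 4 the same change is expected to behave much as it did before, because a 1.1-fold higher number from compound 1 to compound 2 (0.03 log units; within the scatter) left the number essentially where it was. The expected step is therefore a 1.1-fold higher number from compound 3 to compound 4 (0.06 log units; within the scatter), and compound 4 is estimated at 420 nM in this assay, most likely between 200 nM and 900 nM.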

Compound 4, half-maximal inhibitory concentration: 1840 nM
The estimate for compound 4 lay 4.4-fold (0.64 log units) below the measured number; the whole stated range lies below it.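

In this assay the change from hydroxy to methoxy gives a 5.0-fold higher number from compound 3 to compound 4 (0.70 log units; beyond the scatter), so the near-silent result on the core of compound 1 did not carry over to the core of compound 3: the same change on two cores in this assay, a 1.1-fold higher number (0.03 log units; within the scatter) from compound 1 to compound 2 and a 5.0-fold higher number (0.70 log units; beyond the scatter) from compound 3 to compound 4, 4.6-fold (0.66 log units) apart, beyond the scatter of two such steps

In this series, then, the same swap in the same surroundings cannot be assumed to have the same size on a different core: it made no measurable difference on one core, whereas on the other the free hydroxy goes with the lower number and so the stronger inhibitor. This does not show which part of the difference between the two cores is responsible or why the step grows, and two pairs of compounds give no rule for how the change would behave on any further core.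

Only hydroxy and methoxy are shown at this place, so it remains open how an ethoxy group, a longer chain on the oxygen, an amine or a carboxylic acid in place of the hydroxy would behave on either core. From the compounds shown here alone, it also remains open whether the larger step on the core of compound 3 would appear in cell lines other than the one tested here.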